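Changing the aryl group on the shared core of a thiazole acid series

A few compounds are considered here, and "the series" means these few. Any claim that something is new, unique, unknown or untested is made for them only; others in the source may bear on it.

Of the compounds shown here, two have been measured in an in vitro functional assay on HEK285-7 cells for antagonist activity at prostaglandin D2 receptor 2 (Homo sapiens), read by BRET and beta-arrestin recruitment; a lower number here means a stronger inhibitor, a higher number a weaker inhibitor. Compound 1 `O=C(O)Cc1sc(C(c2ccc(F)cc2)c2ccc(F)cc2)nc1-c1ccco1` gives 140 nM in this assay. Within the data shown here, compound 2 `N#Cc1ccc(-c2nc(C(c3ccc(F)cc3)c3ccc(F)cc3)sc2CC(=O)O)cc1` gives 1500 nM, the higher of the two numbers and the only value so far beside compound 1. Among the measured compounds shown here, the one step between them, an 11-fold higher number from compound 1 to compound 2 (1.03 log units; beyond the scatter), shows that what sits at this position of the core can shift the number well beyond the scatter. Compound 3 `CN(C)c1cc(-c2nc(C(c3ccc(F)cc3)c3ccc(F)cc3)sc2CC(=O)O)ccn1` has not been measured yet; it differs from compound 2 in exactly that place: 2-(dimethylamino)pyridin-4-yl in place of 4-cyanophenyl on an aromatic carbon. For the measured compounds named here, no measured step covers this particular exchange, so only the size of the earlier step is a guide; because of an 11-fold higher number from compound 1 to compound 2 (1.03 log units; beyond the scatter) a move of a similar order in either direction would not be surprising. On balance, compound 3 is expected to give about 800 nM, with a range from 200 nM to 3000 nM, which is an expected step of a 1.9-fold lower number from compound 2 to compound 3 (0.27 log units; within the scatter).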

Compound 3, half-maximal inhibitory concentration: > 100000 nM
Compound 3: no number, only a limit; the forecaster's own chance of this, stated with the estimate: 5%; middle value at least 120-fold (2.09 log units) away from the limit.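

For compound 3, this assay returns only a limit of the assay, not a number: the limit of > 100000 nM in this assay, at which 1 of the 3 values shown sits.

Putting 2-(dimethylamino)pyridin-4-yl in place of 4-cyanophenyl gives an at least 66-fold higher number from compound 2 to compound 3 (1.82 log units; beyond the scatter) and putting the same group in place of furan-2-yl gives an at least 710-fold higher number from compound 1 to compound 3 (2.85 log units; beyond the scatter) on the same aromatic carbon of the shared core. This position therefore tolerates less than the earlier step suggested: exchanging one aromatic group here can take a compound all the way to the limit, not merely shift its number.

The compounds shown do not separate the part played by the dimethylamino group from that of the ring nitrogen in the entering group. A plain pyridin-4-yl group and a 4-(dimethylamino)phenyl group at this position would each carry only one of these two features.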